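Swapping the distal heteroaryl ring on the shared core

The compounds below may be only part of what the source reports. "The series", "measured", "known", "first", "only" and "open" are said of these compounds alone.

Of the compounds shown here, three sharing one core have been measured in a functional assay on HEK293 cells for agonist activity at Bombesin receptor subtype-3 (Mus musculus), read by luminescence and calcium flux, with a stated time of 10 min; on this read-out lower numbers stand for an effect already at smaller amounts and higher numbers for an effect only at larger amounts of compound. Compound 1 `CCC(C)(C)Cc1c[nH]c(CCc2ccc(-c3cnccn3)cc2)n1` gives 107 nM, compound 2 `CCC(C)(C)Cc1c[nH]c(CCc2ccc(-n3ccnn3)cc2)n1` gives 111 nM, and compound 3 `CCC(C)(C)Cc1c[nH]c(CCc2ccc(-c3ccc(F)cn3)cc2)n1` gives 105 nM. Compound 3 thus holds the lowest of the three numbers, but its gaps to compound 1 and to compound 2 are within the scatter, so no order among them can be claimed.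

Compound 4 `CCC(C)(C)Cc1c[nH]c(CCc2ccc(-c3cccnc3C(=O)O)cc2)n1` differs from compound 3 in one place: 2-carboxypyridin-3-yl in place of 5-fluoropyridin-2-yl on an aromatic carbon. Every measured step bears on this kind of exchange, since each replaces one heteroaryl group by another at the same aromatic carbon: a 1.0-fold higher number from compound 1 to compound 2 (0.02 log units; within the scatter), a 1.0-fold lower number from compound 1 to compound 3 (0.01 log units; within the scatter) and a 1.1-fold lower number from compound 2 to compound 3 (0.02 log units; within the scatter). None of them moved the read-out beyond the scatter. The present change is nonetheless broader than those. Compound 4 is therefore expected to show a step of a 1.5-fold higher number from compound 3 to compound 4 (0.18 log units; within the scatter), with a wider band of uncertainty than the earlier swaps. The estimate for compound 4 in this assay is 160 nM, expected to lie between 50 nM and 700 nM.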

Compound 4, half-maximal effective concentration: 97 nM
Beside the measured number, compound 4's estimate is 1.6-fold (0.22 log units) above it; the range from low to high includes it.
By their numbers in this assay, from the lowest: compounds 4, 3, 1 and 2 (each within the scatter of the next).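

In this assay, for the compounds shown here, 2-carboxypyridin-3-yl is the first group at this aromatic carbon to carry a hydrogen-bond donor and a double bond outside aromatic rings, and it is also larger than the 5-fluoropyridin-2-yl it replaces. Even so, the result is a 1.1-fold lower number from compound 3 to compound 4 (0.03 log units; within the scatter), and the comparisons with the other two compounds give a 1.1-fold lower number from compound 2 to compound 4 (0.06 log units; within the scatter) and a 1.1-fold lower number from compound 1 to compound 4 (0.04 log units; within the scatter). The position, para to a large group, therefore takes this carboxy-bearing ring as well as the three earlier rings, with compounds 1, 2, 3 and 4 indistinguishable on this read-out and none going against that; nothing available explains this tolerance.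

The compounds shown leave open whether the same holds for an amine, an amide or a longer chain ending in a carboxylic acid at this carbon, or for a plain phenyl ring with no hetero atom. They also leave open whether the carboxy group would be tolerated equally once another part of the shared core is changed, since all four compounds differ only in this one place.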